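A few compounds are considered here, and "the series" means these few. Any claim that something is new, unique, unknown or untested is made for them only; others in the source may bear on it.

Compound 1 `CNC(=O)CC[C@H](NS(=O)(=O)c1ccc([N+](=O)[O-])cc1)C(=O)O`: > 500000 nM (a limit)
Compound 2 `CCNC(=O)CC[C@H](NS(=O)(=O)c1ccc([N+](=O)[O-])cc1)C(=O)O`: 89400 nM

In a functional assay on U-937 cells (Homo sapiens) for cytotoxicity, read by MTT assay, with a stated time of 48 h (on this read-out lower numbers stand for stronger inhibition and higher numbers for weaker inhibition), compound 1 stands only at a limit, > 500000 nM, and has no exact number. Compound 3 `CC(C)CNC(=O)CC[C@H](NS(=O)(=O)c1ccc([N+](=O)[O-])cc1)C(=O)O` differs from it by one change, isopropyl in place of hydrogen on a saturated chain carbon bound to an amide-type nitrogen. Going by the values given here, the one measured step that bears on this is an at least 5.5-fold lower number from compound 1 to compound 2 (0.74 log units; beyond the scatter), with methyl in place of hydrogen at that same place. A step in the same direction, of similar or somewhat larger size, is therefore expected in this assay. The expected step is an at least 10-fold lower number from compound 1 to compound 3 (1.00 log units; beyond the scatter). Compound 3 is estimated at 50000 nM, with an expected range from 15000 nM to 200000 nM.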

Compound 3, half-maximal inhibitory concentration: 93800 nM
For compound 3 the middle estimate is 1.9-fold (0.27 log units) below the measured one; the measured number falls inside the stated range.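

In this assay, isopropyl in place of methyl on a saturated chain carbon bound to an amide-type nitrogen gives a 1.0-fold higher number from compound 2 to compound 3 (0.02 log units; within the scatter), so compound 2 and compound 3 stand level. Isopropyl in place of hydrogen at this place gives an at least 5.3-fold lower number from compound 1 to compound 3 (0.72 log units; beyond the scatter), which matches what methyl did there. The size of that step stays open-ended because compound 1 has only a limit: the limit of > 500000 nM in this assay, at which 1 of the 3 values shown sits.

As far as these compounds go, whether a longer chain, a phenyl ring or a terminal amine at this place would move the number away from the level of compound 2 and compound 3 stays open.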